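The compounds below may be only part of what the source reports. "The series", "measured", "known", "first", "only" and "open" are said of these compounds alone.

Measured so far:
- compound 1 `Cn1c(=O)c(S(=O)(=O)c2ccc(C(=O)O)cc2)cc2cnc(Nc3ccc4[nH]ccc4c3)nc21`: 5000 nM
- compound 2 `Cn1c(=O)c(S(=O)(=O)c2ccc(F)cc2F)cc2cnc(Nc3ccc4c(c3)CC(=O)N4)nc21`: 15000 nM
- compound 3 `O=c1[nH]c2nc(Nc3ccc4[nH]ccc4c3)ncc2cc1S(=O)(=O)c1ccc(F)cc1F`: 15000 nM

All three numbers come from a functional assay on K562 cells (Homo sapiens) for inhibition, read by trypan blue exclusion, with a stated time of 72 h; a lower number here means a stronger inhibitor, a higher number a weaker inhibitor. Compound 1 has the lowest number of the three; compound 2 and compound 3 each sit higher than compound 1 by a gap beyond the usual scatter, so within this small set compound 1 is the strongest inhibitor in this assay. Compound 2 and compound 3 differ from compound 1 in more than one place, so no single step can be read between them and compound 1.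

Compound 4 `Cn1c(=O)c(S(=O)(=O)Nc2ccc(F)cc2)cc2cnc(Nc3ccc4[nH]ccc4c3)nc21` is the next point. It keeps the core of compound 1 and changes only one part: (4-fluorophenyl)amino in place of 4-carboxyphenyl on a sulfonyl sulfur. Among the compounds with values here, no measured pair isolates such a change, so nothing here fixes its size or direction. The expectation for this assay is a step of modest size, most likely toward a weaker inhibitor, since compound 1 already holds the lowest number. For compound 4 the estimated value is 8000 nM, with a range from 2500 nM to 25000 nM, which corresponds to an expected step of a 1.6-fold higher number from compound 1 to compound 4 (0.20 log units; within the scatter).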

Compound 4, half-maximal inhibitory concentration: 5000 nM
Compound 4: the middle estimate sits 1.6-fold (0.20 log units) above what was measured; the measured number falls inside the stated range.
By their numbers in this assay, from the lowest: compounds 1 and 4 (each within the scatter of the next); then compounds 2 and 3 (each within the scatter of the next).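

Within the data shown here, on the sulfonyl sulfur, with the core of compound 1 held fixed, this assay gives the first single-place step: (4-fluorophenyl)amino in place of 4-carboxyphenyl gives no change at the digits printed from compound 1 to compound 4 (within the scatter). For this pair, the 4-carboxyphenyl group and its carbonyl are therefore not needed to keep the number at this level, and a group that enters through nitrogen and carries fluorine serves equally well. No measurement shown accounts for the absence of a visible change at this position.

Still open, from the compounds shown here alone, is whether a saturated amine such as piperidine or morpholine on the sulfonyl sulfur would keep this number, which would test the need for an aromatic ring there. A benzyl amine, with a longer link to the ring, and an unsubstituted anilino group would test the link and the fluorine.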